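From pyridin-2-yl to 4-nitrophenyl on the ring nitrogen

The source may report more compounds than this note shows. Statements on the series, on what has been measured and on what is new or still open speak of the compounds shown alone.

Within the data shown here, compound 2 `CC#CC(CC(=O)O)c1ccc(OCc2ccc(C(=O)N3CCN(c4ccccn4)CC3)s2)cc1` is the only member of the pair that returns a number in a functional assay on HEK293 cells for agonist activity at Free fatty acid receptor 1 (Homo sapiens), read by fluorescence and calcium flux (a higher number here means that more compound is needed for the effect, a lower number that less compound is needed), where compound 2 gives 138 nM. Compound 1 `CC#CC(CC(=O)O)c1ccc(OCc2ccc(C(=O)N3CCN(C)CC3)s2)cc1` gives in this assay only a limit of the assay, > 5000 nM. Among the measured compounds shown here, the single measured step, an at least 36-fold lower number from compound 1 to compound 2 (1.55 log units; beyond the scatter), is therefore bounded by the limit of > 5000 nM in this assay, at which 1 of the 2 values shown sits. Compound 3 `CC#CC(CC(=O)O)c1ccc(OCc2ccc(C(=O)N3CCN(c4ccc([N+](=O)[O-])cc4)CC3)s2)cc1` carries 4-nitrophenyl in place of pyridin-2-yl on an amine nitrogen in a ring. Since an aromatic ring again occupies the ring nitrogen, the step of a 1.6-fold higher number from compound 2 to compound 3 (0.20 log units; within the scatter) is expected to remain small, within or near the scatter. Compound 3 is accordingly estimated at 220 nM, with a range from 60 nM to 1500 nM.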

Compound 3, half-maximal effective concentration: 231 nM
Beside the measured number, compound 3's estimate is 1.1-fold (0.02 log units) below it; the range from low to high includes it.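

Exchanging pyridin-2-yl for 4-nitrophenyl on this amine nitrogen in a ring gives a 1.7-fold higher number from compound 2 to compound 3 (0.22 log units; within the scatter) in this assay, so a six-membered aromatic ring of carbon only, bearing a nitro group, serves here as well as the ring with a hetero atom. Set against methyl, the new group gives an at least 21-fold lower number from compound 1 to compound 3 (1.33 log units; beyond the scatter), a second large step from methyl to an aromatic ring, and one that is only bounded: the limit of > 5000 nM in this assay, at which 1 of the 3 values shown sits.

Open, as far as these compounds go, is whether a cyclohexyl ring or a longer alkyl chain on this nitrogen would reach the same range as these two aromatic rings. Also open, from the compounds shown here alone, is whether plain phenyl would match 4-nitrophenyl.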